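The source may hold more compounds than are shown below. What is called first, only, known or untested is meant among the compounds shown, and "the series" means these compounds.

The measured compounds:
compound 1 `Clc1ccc(C(C2Cc3ccccc3O2)n2cncn2)c(Cl)c1`, in an assay for inhibition of Aromatase (Homo sapiens), tested at 20 uM (a higher number here means more inhibition at the concentration tested (going by the name of the read-out), a lower number less inhibition), compound 1 gives 97.7%
compound 2 `Clc1ccc(C(C2Cc3ccccc3O2)n2cnnn2)cc1`, compound 2 gives 90.3%
compound 3 `Cc1ccc(C(C2Cc3ccccc3O2)n2cnnn2)cc1`, compound 3 gives 67.2%

Compound 2 stands second highest of these three numbers: the number of compound 1 is within the scatter of it, whereas the step of a number 23.1 percentage points lower from compound 2 to compound 3 (beyond the scatter) lies beyond it. Compound 4 `Clc1ccc(C(C2Cc3ccccc3O2)n2cnnn2)c(Cl)c1` differs from compound 2 by chloro in place of hydrogen on an aromatic carbon. Going by the values given here, no measured step shows chloro in place of hydrogen; the one step known, methyl for chloro, is a different change and gives no direct guide. Compound 1 also carries two chloro groups, though its core differs elsewhere, and its number is within the scatter of compound 2. The step of a number 2.7 percentage points higher from compound 2 to compound 4 (within the scatter) is therefore expected to remain within the scatter. Compound 4 is estimated at 93%, between 82% and 99%.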

Compound 4, a percentage reported as inhibition, at one concentration (the size of the read-out at that concentration, not a potency): 82.3%
Compound 4: middle estimate off by 10.7 percentage points, on the high side; low and high end bracket the measured number.
By their numbers in this assay, from the lowest: compound 3; then compounds 4, 2 and 1 (each within the scatter of the next, the first and the last beyond it).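

In this assay, chloro in place of hydrogen on an aromatic carbon, ortho to a large group, gives a number 8 percentage points lower from compound 2 to compound 4 (within the scatter) and so shows no change that can be told from the scatter. With both chloro groups present, 1H-tetrazol-1-yl in place of 1H-1,2,4-triazol-1-yl gives a number 15.4 percentage points lower from compound 1 to compound 4 (beyond the scatter) and thus shows that the group on the saturated chain carbon matters here. Nothing given explains either step. Open, on these data alone, is whether this group swap gives a similar step without the added chloro, and whether an amine or a methoxy group on that aromatic carbon would leave the number within the scatter.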